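This account rests on a few compounds, and the source may have more. Where it says the series, first, only, none or still open, it means among the compounds named here.

In an ADME assay on microsomes (Mus musculus) for metabolic stability (on this read-out lower numbers stand for slow clearance and higher numbers for fast clearance), compound 1 `Cc1cc(C(F)(F)F)c2cccc(OCc3c(Cl)ccc(S(=O)(=O)N4C[C@@H](C)O[C@@H](C)C4)c3Cl)c2n1` gives 933 mL/min/kg and compound 2 `Cc1cc(C(F)(F)F)c2cccc(OCc3c(Cl)ccc(S(=O)(=O)N4CCC(C#N)CC4)c3Cl)c2n1` gives 1720 mL/min/kg while compound 3 `CNC(=O)[C@@H]1CCCN1S(=O)(=O)c1ccc(Cl)c(COc2cccc3c(-c4nccn4C)cc(C)nc23)c1Cl` gives 917 mL/min/kg and all three numbers lie within the usual scatter of one another. Compound 3 therefore stands level with the other two, with no order among them. Compound 4 `CNC(=O)[C@@H]1CCCN1S(=O)(=O)c1ccc(Cl)c(COc2cccc3c(-c4ccncc4)cc(C)nc23)c1Cl` differs from compound 3 in one place, with pyridin-4-yl in place of 1-methyl-1H-imidazol-2-yl on an aromatic carbon, opposite the ring nitrogen pyridin-4-yl in place of 1-methyl-1H-imidazol-2-yl on an aromatic carbon and everything else unchanged. Going by the values given here, the only measured step is a 1.8-fold higher number from compound 1 to compound 2 (0.27 log units; within the scatter) and it belongs to 4-cyanopiperidin-1-yl in place of 2,6-dimethylmorpholin-4-yl on a sulfonyl sulfur. Among the compounds with values here, that step lies elsewhere in the structure, so it bears on this change only indirectly, and no measured step covers the aromatic carbon concerned. Compound 1 carries a trifluoromethyl group on that carbon and also differs from compound 3 at the sulfonyl sulfur, yet the two values remain within the scatter. In this assay the expected step is a 1.0-fold higher number from compound 3 to compound 4 (0.00 log units; within the scatter) which means none beyond the scatter, with no direction favoured. For compound 4 the estimate is 920 mL/min/kg and the expected range runs from 460 mL/min/kg to 1850 mL/min/kg as estimated here.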

Compound 4, clearance: 550 mL/min/kg
Beside the measured number, compound 4's estimate is 1.7-fold (0.22 log units) above it; the measured number falls inside the stated range.
By their numbers in this assay, from the lowest: compounds 4, 3, 1 and 2 (each within the scatter of the next, the first and the last beyond it).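

In this assay, going by these compounds alone, the first measured step at this aromatic carbon, opposite the ring nitrogen, is a 1.7-fold lower number from compound 3 to compound 4 (0.22 log units; within the scatter), with pyridin-4-yl in place of 1-methyl-1H-imidazol-2-yl. Within the data shown here, the earlier step, a 1.8-fold higher number from compound 1 to compound 2 (0.27 log units; within the scatter), concerned only the group on the sulfonyl sulfur, so this is the first direct reading at this position: with the rest of the molecule unchanged, a six-membered aromatic ring with 1 hetero atom and a five-membered aromatic ring with 2 hetero atoms, each of 6 heavy atoms, cannot be told apart on this read-out. The compounds shown offer no measured basis for explaining this result.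

On these data alone, whether a ring with no nitrogen, such as phenyl, or a smaller group such as an amine or a carboxylic acid on this aromatic carbon would give a step beyond the scatter remains open. As far as these compounds go, it is also open whether pyridin-4-yl would give the same reading with 4-cyanopiperidin-1-yl or 2,6-dimethylmorpholin-4-yl on the sulfonyl sulfur in place of the group that compound 3 and compound 4 share.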